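This account rests on a few compounds, and the source may have more. Where it says the series, first, only, none or still open, it means among the compounds named here.

Three compounds have been measured in an assay on isolated protein for inhibition of Dihydrofolate reductase (Mus musculus); on this read-out higher numbers stand for higher potency (the scale is a negative logarithm) and lower numbers for lower potency:

Compound 1, `CC1(C)N=C(N)N=C(N)N1c1ccc(CCCCc2ccccc2)c(Cl)c1`, gives 7.92.
Compound 2, `CC1(C)N=C(N)N=C(N)N1c1ccc(OCCCCCOc2ccc(S(=O)(=O)F)cc2)c(Cl)c1`, gives 7.57.
Compound 3, `CCN(CC)C(=O)NCc1cccc(N2C(N)=NC(N)=NC2(C)C)c1`, gives 6.11.

Compound 1 has the highest of these three numbers. Compound 2 comes nearest, with a number lower than that of compound 1 by a gap beyond the usual scatter, and compound 3 is the furthest away, well below both. No two of the measured compounds differ from each other in just one place, so no single change has yet been tied to a shift in the numbers.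

Compound 4, `CC1(C)N=C(N)N=C(N)N1c1ccc(CCCCc2ccccc2S(=O)(=O)F)c(Cl)c1`, has not yet been measured. It comes from compound 1 by one change: fluorosulfonyl in place of hydrogen on an aromatic carbon. The group enters on the outer ring that sits at the end of the four-carbon chain, ortho to that large group.

A hint comes from compound 2, which also carries a fluorosulfonyl group on an outer ring and gives a number a little below compound 1, though its chain differs as well. The expectation for compound 4 is a small step down or none beyond the scatter, a number 0.22 log units lower from compound 1 to compound 4 (within the scatter). Compound 4 is thus estimated at 7.7, within a range from 7 to 8.4.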

Compound 4, logarithm of the reciprocal of the active concentration, log(1/C): 7.77
Compound 4: the middle estimate sits 0.07 log units below what was measured, and the stated range covers the measured number.
By their numbers in this assay, from the lowest: compound 3; then compounds 2, 4 and 1 (each within the scatter of the next, the first and the last beyond it).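

In this assay, within the data shown here, fluorosulfonyl in place of hydrogen on an aromatic carbon gives a number 0.15 log units lower from compound 1 to compound 4 (within the scatter), the first single change in this set that can be tied to a step. It shows that this position on the outer ring, ortho to a large group, accepts fluorosulfonyl with no step beyond the scatter, something compound 2 could not show, since its chain differs from that of compound 1 as well. Nothing measured here gives a reason for this result.

Still open, on these data alone, is whether other groups at this same position, such as an amine or a carboxylic acid, would also leave the number within the scatter of compound 1. Also open, as far as these compounds go, is whether fluorosulfonyl would give a similar result elsewhere on the outer ring, or with a longer chain leading to that ring.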